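A few compounds are considered here, and "the series" means these few. Any claim that something is new, unique, unknown or untested is made for them only; others in the source may bear on it.

Measured so far in an assay on isolated protein for inhibition of long-chain fatty acid transport protein 1 (Homo sapiens); on this read-out higher numbers stand for weaker inhibition and lower numbers for stronger inhibition:
- compound 1 `CCn1c(CNc2ccccc2)nnc1SCc1nc2cc(C(=O)C(C)C)ccc2o1`: 600 nM
- compound 2 `CCn1c(CNc2ccccc2)nnc1SCC(=O)Nc1ccc(C(=O)NC)cc1`: > 1000 nM, a limit of the assay
- compound 3 `CCn1nnc(-c2ccc(NC(=O)CSc3nnc(CNc4ccccc4)n3CC)cc2)n1`: > 1000 nM, a limit of the assay

Going by the values given here, compound 1 stands as the only number among the three results in this assay; the other two sit at the limit of > 1000 nM in this assay, at which 2 of the 3 values shown sit. Compound 2 gives only a limit. Compound 3 likewise gives only a limit. Among the compounds with values here, the one step that can be read across a single change, a step that the two limits leave unreadable from compound 2 to compound 3, cannot be sized, and it concerns a different part of the molecule than the change examined here.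

Compound 4 `CC/C(=N/O)c1ccc2oc(CSc3nnc(CNc4ccccc4)n3CC)nc2c1` differs from compound 1 by a group of 5 heavy atoms (3 carbon, 1 nitrogen, 1 oxygen; no ring) in place of a group of 5 heavy atoms (4 carbon, 1 oxygen; no ring), on an aromatic carbon. Within the data shown here, no measured step covers a change of this kind, and the two limit values give no scale for it. The expectation rests on compound 1 alone and on the size of the exchanged groups, which is equal: no step beyond the usual scatter is expected, no change at the digits printed from compound 1 to compound 4 (within the scatter). Compound 4 is therefore estimated at 600 nM, within a range from 200 nM to 1800 nM.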

Compound 4, half-maximal inhibitory concentration: 260 nM
Estimate against measurement, compound 4: 2.3-fold (0.36 log units) above; measured number inside the range.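

In this assay, the aromatic carbon carrying isopropylcarbonyl proves sensitive to an exchange of equal heavy-atom count, with a 2.3-fold lower number from compound 1 to compound 4 (0.36 log units; beyond the scatter) and thus stronger inhibition. The two groups share 5 heavy atoms and 1 double bond outside aromatic rings, but the entering group has nitrogen in place of one carbon and adds 1 hydrogen-bond donor; this single step does not show which difference matters. Compound 2 and compound 3 give no scale for the step, as each gives only a limit and the step between them cannot be read: the limit of > 1000 nM in this assay, at which 2 of the 4 values shown sit.

Open, as far as these compounds go, is whether the hydrogen-bond donor matters, which the oxime's methyl ether on the same aromatic carbon could test. Also open, from the compounds shown here alone, is how a carboxylic acid, an amine or a longer chain at this place compares with compound 4.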